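This account rests on a few compounds, and the source may have more. Where it says the series, first, only, none or still open, it means among the compounds named here.

Measured compounds in a functional assay on HEK293 cells for agonist activity at Vasopressin V2 receptor (Homo sapiens), read by a luciferase reporter and cAMP accumulation; a lower number here means that less compound is needed, a higher number that more compound is needed for the effect:
- compound 1, `Cc1cc(C(=O)N2CCCCc3ccccc32)ccc1CNC(=O)Nc1c(F)cccc1F`, gives 2.1 nM
- compound 2, `Cc1cc(C(=O)N2CCCCc3ccccc32)ccc1CNC(=O)NCC(=O)O`, gives 180 nM
- compound 3, `COC(=O)[C@@H]1CCCN1C(=O)NCc1ccc(C(=O)N2CCCCc3ccccc32)cc1C`, gives 100 nM

Compound 3 holds the second highest of the three numbers. Its nearest neighbour is compound 2, the step of a 1.8-fold lower number from compound 2 to compound 3 (0.26 log units; within the scatter) lying within the scatter; its furthest is compound 1, with a 48-fold higher number from compound 1 to compound 3 (1.68 log units; beyond the scatter) well beyond it. The other large step, an 86-fold higher number from compound 1 to compound 2 (1.93 log units; beyond the scatter), likewise reflects the loss of the 2,6-difluorophenyl urea substituent.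

Compound 4, `Cc1cc(C(=O)N2CCCCc3ccccc32)ccc1CNC(=O)N1CC(=O)C[C@H]1C(=O)N(C)C`, changes (2-(dimethylcarbamoyl)-4-oxopyrrolidin-1-yl in place of 2-(methoxycarbonyl)pyrrolidin-1-yl on a carbonyl carbon). Going by the values given here, both compound 3 and compound 4 carry a pyrrolidinyl group on that carbonyl carbon, so the single step that bears directly on the change is a 1.8-fold lower number from compound 2 to compound 3 (0.26 log units; within the scatter), which was within the scatter; the large steps from compound 1 concern a different substitution and give no guidance here. Among the compounds with values here, no measured pair tests the exchange of a methoxycarbonyl for a dimethylcarbamoyl group or the added oxo group. The expectation for compound 4 is therefore a step of a 1.3-fold higher number from compound 3 to compound 4 (0.11 log units; within the scatter), that is, none beyond the scatter. Compound 4 is estimated at 130 nM, in the range 40 nM to 450 nM.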

Compound 4, half-maximal effective concentration: 27 nM
Compound 4: middle estimate off by 4.8-fold (0.68 log units), on the high side, outside the stated range (below it).
By their numbers in this assay, from the lowest: compound 1; then compound 4; then compounds 3 and 2 (each within the scatter of the next).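

At this carbonyl carbon, the two groups built on a pyrrolidin-1-yl ring do not read alike: 2-(dimethylcarbamoyl)-4-oxopyrrolidin-1-yl in place of 2-(methoxycarbonyl)pyrrolidin-1-yl gives a 3.7-fold lower number from compound 3 to compound 4 (0.57 log units; beyond the scatter), whereas compound 2 and compound 3 had stayed within the scatter of each other. The new group also separates from the (carboxymethyl)amino group, with a 6.7-fold lower number from compound 2 to compound 4 (0.82 log units; beyond the scatter), but does not match the (2,6-difluorophenyl)amino group, with a 13-fold higher number from compound 1 to compound 4 (1.11 log units; beyond the scatter), so compound 1 keeps the lowest number of the four. No evidence at hand accounts for these steps.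

The step from compound 3 to compound 4 combines the change from ester to dimethylcarbamoyl with the added ring carbonyl, and the compounds shown do not separate the two. Also open, on these data alone, is how a pyrrolidine bearing a free carboxylic acid or a primary amide at this place would read.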